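Adding a trifluoromethyl to the weakest chalcone of the series

The source may report more compounds than this note shows. Statements on the series, on what has been measured and on what is new or still open speak of the compounds shown alone.

Three compounds sharing one core were tested in a functional assay on SK-OV-3 cells (Homo sapiens) for antiproliferative activity, read by MTT assay, with a stated time of 24 h; on this read-out lower numbers stand for stronger inhibition and higher numbers for weaker inhibition. Compound 1 `COc1cccc(/C=C/C(=O)c2ccc(OC)c3c2OC(C)(C)C=C3)c1` gives 9360 nM, and compound 2 `COc1ccc(C(=O)/C=C/c2cccc([N+](=O)[O-])c2)c2c1C=CC(C)(C)O2` gives 9720 nM. Compound 3 `COc1ccc(C(=O)/C=C/c2ccccc2)c2c1C=CC(C)(C)O2` reaches only the limit of the assay, > 10000 nM, so no number is known for it. Compound 4 `COc1ccc(C(=O)/C=C/c2cccc(C(F)(F)F)c2)c2c1C=CC(C)(C)O2` differs from compound 3 by a single change: trifluoromethyl in place of hydrogen on an aromatic carbon. Among the compounds with values here, two measured steps concern the same position of the ring. Removing the methoxy gave an at least 1.0-fold higher number from compound 1 to compound 3 (0.02 log units; that floor lies within the scatter), and removing the nitro gave an at least 1.0-fold higher number from compound 2 to compound 3 (0.01 log units; that floor lies within the scatter); both end at the limit (the limit of > 10000 nM in this assay, at which 1 of the 3 values shown sits), so neither shows a shift beyond the scatter. A group placed at this position has therefore changed little so far, whether it was a methoxy or a nitro. On that basis, the expected step to compound 4 in this assay is an at least 1.0-fold lower number from compound 3 to compound 4 (0.02 log units; that floor lies within the scatter), meaning no change beyond the scatter. Compound 4 is accordingly estimated at 9500 nM, with a range from 4000 nM to 22000 nM.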

Compound 4, half-maximal inhibitory concentration: 9330 nM
Beside the measured number, compound 4's estimate is 1.0-fold (0.01 log units) above it; low and high end bracket the measured number.
By their numbers in this assay, from the lowest: compounds 4, 1 and 2 (each within the scatter of the next). At a limit, above all of these: compound 3.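

In this assay, trifluoromethyl in place of nitro gives a 1.0-fold lower number from compound 2 to compound 4 (0.02 log units; within the scatter), and trifluoromethyl in place of methoxy gives a 1.0-fold lower number from compound 1 to compound 4 (0.00 log units; within the scatter), so a third group at this position falls within the scatter of the first two. Against hydrogen only a floor can be read, an at least 1.0-fold lower number from compound 3 to compound 4 (0.03 log units; that floor lies within the scatter), so how far any of these three groups truly moves the number away from hydrogen stays unknown. Compound 3 itself stands at a limit, not at a number: the limit of > 10000 nM in this assay, at which 1 of the 4 values shown sits.

The compounds shown leave open whether a group of another kind at this position, such as an amine or a carboxylic acid, would shift the number beyond the scatter. Also open, on these data alone, is whether a change on the shared core, rather than at this position, would do so.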